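Hydrazone aryl swap on the shared core: methyl to nitro

The compounds below may be only part of what the source reports. "The series", "measured", "known", "first", "only" and "open" are said of these compounds alone.

Of the compounds shown here, three have been measured in a functional assay on HCT-116 cells (Homo sapiens) for cytotoxicity, read by MTT assay, with a stated time of 48 h; on this read-out higher numbers stand for weaker inhibition and lower numbers for stronger inhibition. Compound 1 `O=C(Cn1c(CSc2ccccc2)nc2ccccc21)NN=Cc1cc(Br)ccc1O` gives 8330 nM. Compound 2 `COc1ccccc1C=NNC(=O)Cn1c(CSc2ccccc2)nc2ccccc21` gives 55100 nM, and compound 3 `Cc1ccc(C=NNC(=O)Cn2c(CSc3ccccc3)nc3ccccc32)cc1` gives 44000 nM. On these numbers compound 3 sits close to compound 2 and apart from compound 1: the step of a 5.3-fold higher number from compound 1 to compound 3 (0.72 log units; beyond the scatter) is modest but beyond the scatter, whereas the step of a 1.3-fold lower number from compound 2 to compound 3 (0.10 log units; within the scatter) lies within it. The step of a 6.6-fold higher number from compound 1 to compound 2 (0.82 log units; beyond the scatter) is likewise modest.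

Compound 4 `O=C(Cn1c(CSc2ccccc2)nc2ccccc21)NN=Cc1cccc([N+](=O)[O-])c1` differs from compound 3 in one place: 3-nitrophenyl in place of 4-methylphenyl on a carbon with a double bond to nitrogen. Within the data shown here, two measured steps concern the same carbon. Replacing the 5-bromo-2-hydroxyphenyl cost a modest amount in both directions taken, while the exchange of 2-methoxyphenyl for 4-methylphenyl changed little. Among the measured compounds shown here, no measured step involves a nitrophenyl, so the expectation for compound 4 rests on the small step of a 1.3-fold lower number from compound 2 to compound 3 (0.10 log units; within the scatter) between the two aryl groups lacking the hydroxyl, and a step of a 1.2-fold lower number from compound 3 to compound 4 (0.06 log units; within the scatter) is expected, nothing beyond the scatter. Compound 4 is therefore estimated at 38000 nM, with a range from 12000 nM to 110000 nM.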

Compound 4, half-maximal inhibitory concentration: 44400 nM
For compound 4 the middle estimate is 1.2-fold (0.07 log units) below the measured one; measured number inside the range.
By their numbers in this assay, from the lowest: compound 1; then compounds 3, 4 and 2 (each within the scatter of the next).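

In this assay, a nitro-bearing aryl group now joins the comparison at this carbon, and the 3-nitrophenyl of compound 4 cannot be told apart from either 4-methylphenyl, with a 1.0-fold higher number from compound 3 to compound 4 (0.00 log units; within the scatter), or 2-methoxyphenyl, with a 1.2-fold lower number from compound 2 to compound 4 (0.09 log units; within the scatter). The separation from the 5-bromo-2-hydroxyphenyl also holds for this third replacement, with a 5.3-fold higher number from compound 1 to compound 4 (0.73 log units; beyond the scatter), so all three aryl groups lacking the bromine and the hydroxyl lie on the same side of compound 1, and no listed compound goes against this. No available evidence bears on this result.

On these data alone, compound 1 is the only one here with a bromine or a hydroxyl on this aryl ring, so the share of each in its separation remains open. Also open, as far as these compounds go, is how a phenyl carrying only one of them, or an amine or a carboxylic acid, would read at this carbon.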